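Swapping Fluoro for Bromo on a Growth Inhibitor

This account rests on a few compounds, and the source may have more. Where it says the series, first, only, none or still open, it means among the compounds named here.

Three related compounds have been measured in a functional assay on A549 cells (Homo sapiens) for inhibition, read by MTT assay, with a stated time of 48 h (a higher number here means a weaker inhibitor of growth, a lower number a stronger inhibitor of growth), and a fourth is still waiting for its number. Compound 1 (`COc1cc(C2=NN(C(=O)c3ccc(C)nc3)C(c3cn(C)c4ccccc34)C2)cc(OC)c1OC`) gives 230 nM and compound 2 (`COc1ccc(C2=NN(C(=O)c3cccnc3)C(c3cn(C)c4ccc(Br)cc34)C2)cc1OC`) gives 2380 nM in this test. Compound 3 (`COc1ccc2c(c1)c(C1CC(c3ccc(F)cc3)=NN1C(=O)c1ccc(OC)nc1)cn2C`) gives 710 nM and so holds the second highest of the three numbers, with its gaps to both of the others lying beyond the scatter. Among the measured compounds shown here, those three compounds differ from one another in more than one place, so no measured pair isolates a single change.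

Compound 4 (`COc1ccc2c(c1)c(C1CC(c3ccc(Br)cc3)=NN1C(=O)c1ccc(OC)nc1)cn2C`) differs from compound 3 in one place only: bromo in place of fluoro on an aromatic carbon; in words, bromo in place of fluoro on an aromatic carbon, para to a large group, which turns a 4-fluorophenyl into a 4-bromophenyl. For the measured compounds named here, no tested pair shows what this swap does, so the expectation is a cautious one, anchored on compound 3 at 710 nM as the closest relative. In this assay the expected step is a 1.1-fold lower number from compound 3 to compound 4 (0.04 log units; within the scatter) and it is expected to stay within the scatter, with no firm direction. The estimated value for compound 4 is 650 nM with an expected range from 260 nM to 1600 nM for a real measurement.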

Compound 4, concentration for 50% growth inhibition: > 10000 nM
Compound 4: a limit, no number (the forecaster's own chance of this, stated with the estimate: 2%); middle value at least 15-fold (1.18 log units) away from the limit.
By their numbers in this assay, from the lowest: compound 1; then compound 3; then compound 2. At a limit, above all of these: compound 4.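

In this assay, among the compounds shown here, the exchange of fluoro for bromo on the aromatic carbon para to a large group is the first single change that can be read on its own, and it gives an at least 14-fold higher number from compound 3 to compound 4 (1.14 log units; beyond the scatter). The reading for compound 4 is a limit of the assay and not a number: the limit of > 10000 nM in this assay, at which 1 of the 4 values shown sits. The earlier compounds shown here differ from one another in more than one place and could not isolate any one group, whereas this pair shows that exchanging one heavy atom for one heavy atom at this position, with no change in the count of hydrogen-bond donors or acceptors, is enough to separate a compound with a measurable number from one at the limit.

Going by these compounds, what remains open is whether bromo stands alone in this effect, as a chloro group or an amine at the same position would be needed to show whether growth inhibition falls away with other replacements too. The data also give no cause for the step and do not tell whether the same swap would have a similar effect in compounds with the other substituents seen in compound 1 and compound 2.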